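The source may hold more compounds than are shown below. What is called first, only, known or untested is meant among the compounds shown, and "the series" means these compounds.

Measured so far in an ADME assay on J774 cells (Mus musculus) for cytotoxicity; a lower number here means that less compound is needed, a higher number that more compound is needed for the effect:
Compound 1 `CCCCc1cc2c(=O)c(C(=O)OCC)c[nH]c2cc1OCCOc1ccccc1`: > 20000 nM, a limit
Compound 2 `CCCCc1cc2c(=O)c(C(=O)OC)c[nH]c2cc1OCCOc1ccccc1`: > 20000 nM, a limit

Compound 2 has no exact number, and its value of > 20000 nM is a limit. Compound 1 is in the same position, with > 20000 nM also a limit. Together these two results define (the limit of > 20000 nM in this assay, at which 2 of the 2 values shown sit).

The next compound, compound 3 `CCCCc1cc2c(=O)c(C(=O)O)c[nH]c2cc1OCCOc1ccccc1`, differs from compound 2 by hydrogen in place of methyl on an oxygen next to a carbonyl group. This places hydrogen in place of methyl on an oxygen next to a carbonyl group, taking methoxycarbonyl to carboxy.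

Among the compounds with values here, only one measured step bears on this change: a step that the two limits leave unreadable from compound 1 to compound 2. It also removes a carbon from the same group, but it provides no size to carry over. With no readable step as a guide, no clear change is expected in this assay, and no direction can be supported. The expected step is a number no higher from compound 2 to compound 3 (the limit leaves the size open). The most likely outcome is another limit rather than a number. For compound 3 the estimated value is 20000 nM, with an expected range of 11000 nM to 40000 nM.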

Compound 3, half-maximal effective concentration: > 20000 nM
Compound 3: no number, only a limit; the forecaster's own chance of this, stated with the estimate: 85%; the middle value sits exactly at the limit.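

No new step can be read in this assay between compound 3 and compound 1 or compound 2, as all three stand at one limit: the limit of > 20000 nM in this assay, at which 3 of the 3 values shown sit.
The compounds shown leave open whether the change from methoxycarbonyl to carboxy has any effect in this assay at all, and what exact value each of the three compounds would give.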